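Moving the chlorine on compound 2

The source may report more compounds than this note shows. Statements on the series, on what has been measured and on what is new or still open speak of the compounds shown alone.

compound 1 `COc1cccc(-c2nc(SCC(=O)c3sc(-c4ccccc4)nc3C)[nH]c(=O)c2C#N)c1`: 59700 nM
compound 2 `Cc1nc(-c2ccccc2)sc1C(=O)CSc1nc(-c2cccc(Cl)c2)c(C#N)c(=O)[nH]1`: 28200 nM

These values come from a functional assay on U-87MG ATCC cells for antiproliferative activity against U-87 MG (Homo sapiens), read by MTT assay, with a stated time of 48 h; a higher number here means a weaker inhibitor, a lower number a stronger inhibitor. Of the two compounds, compound 2 has the lower number, 28200 nM, which makes it the stronger inhibitor of this pair.

Compound 3 `Cc1nc(-c2ccccc2)sc1C(=O)CSc1nc(-c2ccc(Cl)cc2)c(C#N)c(=O)[nH]1` has the same atoms as compound 2, joined differently: 4-chlorophenyl in place of 3-chlorophenyl on an aromatic carbon. The chlorine stays, but 4-chlorophenyl takes the place of 3-chlorophenyl.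

Going by the values given here, only one measured step offers any guidance: a 2.1-fold lower number from compound 1 to compound 2 (0.33 log units; beyond the scatter). It is modest and comes from chloro in place of methoxy on an aromatic carbon. It exchanges one group for another, so it does not show what moving the chlorine does. A small step is therefore expected in this assay, possibly within the scatter, with neither direction favoured.

For compound 3 the estimated value is 30000 nM, with an expected range from 12000 nM to 70000 nM. This estimate means an expected 1.1-fold higher number from compound 2 to compound 3 (0.03 log units; within the scatter).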

Compound 3, half-maximal inhibitory concentration: 43400 nM
Compound 3: middle estimate off by 1.4-fold (0.16 log units), on the low side; low and high end bracket the measured number.
By their numbers in this assay, from the lowest: compounds 2, 3 and 1 (each within the scatter of the next, the first and the last beyond it).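

Moving the chlorine gives a 1.5-fold higher number from compound 2 to compound 3 (0.19 log units; within the scatter) in this assay, so at this position the 3-chlorophenyl and 4-chlorophenyl groups cannot be told apart in this read-out. The change from 3-methoxyphenyl to 4-chlorophenyl gives a 1.4-fold lower number from compound 1 to compound 3 (0.14 log units; within the scatter) and is also small, so the modest separation from compound 1 is seen for compound 2 but not for compound 3, even though compounds 2 and 3 cannot themselves be separated. No measurement available here explains these numbers.

From the compounds shown here alone, all three compounds carry a phenyl ring with a single chlorine or methoxy group at this position, so the effect of a very different group there, such as an amine or a carboxylic acid, remains open. Going by these compounds, whether a longer chain in place of the phenyl ring would shift the number beyond the scatter also remains open.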